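Demethylation on two related cores: one step, one estimate

The source may report more compounds than this note shows. Statements on the series, on what has been measured and on what is new or still open speak of the compounds shown alone.

Measured compounds in a functional assay on A-431 cells (Homo sapiens) for antiproliferative activity, read by MTT assay, with a stated time of 72 h; a higher number here means a weaker inhibitor, a lower number a stronger inhibitor:
compound 1, `COc1cc(OC)c2c(=O)n(-c3cccc(C(=O)N4CCCCC4)c3)ccc2c1`, gives 15300 nM
compound 2, `COc1cc(O)c2c(=O)n(-c3cccc(C(=O)N4CCCCC4)c3)ccc2c1`, gives 2250 nM
compound 3, `COc1cc2c(c(OC)c1)C(=O)N(c1cccc(C(=O)N3CCCCC3)c1)CC2`, gives 10800 nM

Compounds 1 and 2 share one core and differ in a single place:
hydrogen in place of methyl on an oxygen on an aromatic ring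
This change produced a 6.8-fold lower number from compound 1 to compound 2 (0.83 log units; beyond the scatter), a step that lies beyond the scatter of this assay.

Compound 3 carries a different core; how the core of compound 3 differs from the core of compound 1 is not broken down here. In this assay compound 3 sits close to compound 1, and the gap between the two is within the scatter, so no order between them is claimed. Compound 2 stands apart from compound 3 by a margin beyond the scatter.

Compound 4, `COc1cc(O)c2c(c1)CCN(c1cccc(C(=O)N3CCCCC3)c1)C2=O`, has not yet been measured. It relates to compound 3 exactly as compound 2 relates to compound 1:
hydrogen in place of methyl on an oxygen on an aromatic ring
The place of the change reads the same in both pairs, so this is the same change made on the core of compound 3.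

For the measured compounds named here, the step from compound 3 to compound 4 is expected to be a 6.0-fold lower number from compound 3 to compound 4 (0.78 log units; beyond the scatter), judged beside the one measured step, because the only precedent is a 6.8-fold lower number from compound 1 to compound 2 (0.83 log units; beyond the scatter) on the other core. With compound 3 at 10800 nM as the starting point, compound 4 is expected to give about 1800 nM in this assay, with a likely range estimated from 700 nM to 5000 nM.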

Compound 4, half-maximal inhibitory concentration: 5320 nM
For compound 4 the middle estimate is 3.0-fold (0.47 log units) below the measured one; the whole stated range lies below it.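

In this assay, the change from methoxy to hydroxy on the core of compound 3 gave a 2.0-fold lower number from compound 3 to compound 4 (0.31 log units; beyond the scatter), so the number fell on both cores and the direction of the step carried over. The size did not carry over, and the two steps cannot be treated as one transferable increment: the same change on two cores in this assay, a 6.8-fold lower number (0.83 log units; beyond the scatter) from compound 1 to compound 2 and a 2.0-fold lower number (0.31 log units; beyond the scatter) from compound 3 to compound 4, 3.3-fold (0.52 log units) apart, beyond the scatter of two such steps. This shows that, for these two pairs, the core on which the change is made goes with a real difference in how much the number falls, but it does not show which feature of the two cores is responsible, nor does one pair on each core show how the change would behave on any third core.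

The compounds shown hold only methyl or hydrogen on this oxygen, so it remains open how an ethyl group there, or an amine or a carboxylic acid in place of the methoxy, would read on either core. Going by these compounds, all four compounds also keep the same amide group and the second methoxy group, so it remains open whether the difference between the two steps would persist if either of those were replaced, for instance the methoxy by a fluorine.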